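Replacing methyl on the carbonyl carbon of compound 3

A few compounds are considered here, and "the series" means these few. Any claim that something is new, unique, unknown or untested is made for them only; others in the source may bear on it.

Values in a functional assay on MCF7 cells (Homo sapiens) for cytotoxicity, read by MTT assay, with a stated time of 48 h (on this read-out higher numbers stand for weaker inhibition and lower numbers for stronger inhibition), so far
compound 1 `CCN(CC)C(=S)SC(CC(=O)c1ccccc1)c1ccc(Br)cc1` gives 80 nM
compound 2 `CCN(CC)C(=S)SC(CC(=O)c1ccccc1)c1ccc(Cl)cc1` gives 120 nM
compound 3 `CCN(CC)C(=S)SC(CC(C)=O)c1ccccc1` gives 23000 nM

Compound 3 has the highest number of the three, beyond the scatter from both compound 1 and compound 2. The next structure is compound 4 `CCN(CC)C(=S)SC(CC(=O)c1ccc(Cl)cc1)c1ccccc1`, with 4-chlorophenyl in place of methyl on a carbonyl carbon. Among the measured compounds shown here, the only measured step is a 1.5-fold higher number from compound 1 to compound 2 (0.18 log units; within the scatter) and it stays within the scatter, so it says little about this change. Compound 1 and compound 2 also hold a six-membered aromatic ring on that carbonyl carbon, but they differ from compound 3 elsewhere too. For the measured compounds named here, no measured step isolates the replacement, and no measured compound has a halogen on the ring at the carbonyl carbon. Compound 2 at 120 nM still supports expecting a large step to a lower number in this assay here. The expected step is a 77-fold lower number from compound 3 to compound 4 (1.88 log units; beyond the scatter) and it remains uncertain. For compound 4 the estimated value is 300 nM with an expected range of 60 nM to 2500 nM on this reading.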

Compound 4, half-maximal inhibitory concentration: 40 nM
Estimate against measurement, compound 4: 7.5-fold (0.88 log units) above; the whole stated range lies above it.
By their numbers in this assay, from the lowest: compounds 4, 1 and 2 (each within the scatter of the next, the first and the last beyond it); then compound 3.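

In this assay, 4-chlorophenyl in place of methyl on the carbonyl carbon gives a 580-fold lower number from compound 3 to compound 4 (2.76 log units; beyond the scatter), a large step and the first measured one that isolates this position. Among the compounds shown here, the earlier compounds also held an aromatic ring on that carbonyl carbon but differed from compound 3 elsewhere too, so only this step ties stronger inhibition to the group on the carbonyl carbon alone. No available evidence accounts for the size of this step.

From the compounds shown here alone, the step brings in the six-membered aromatic ring and the chlorine together, so their separate shares remain open. Going by these compounds, it is also open how an unsubstituted phenyl, a saturated ring such as cyclohexyl, or a longer chain such as propyl on the carbonyl carbon would compare with methyl and 4-chlorophenyl.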